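Compound 4: pyridin-4-yl in place of 3-methyl-1,2-oxazol-5-yl

This account rests on a few compounds, and the source may have more. Where it says the series, first, only, none or still open, it means among the compounds named here.

In a physicochemical assay for lipophilicity, read by HPLC, measured as octanol-water partition, at pH 7.2 (on this read-out lower numbers stand for lower lipophilicity and higher numbers for higher lipophilicity), compound 1 (`O=C(Nc1ccnc(C(F)(F)F)c1)Nc1ccc(F)c(C(F)(F)F)c1`) gives 3.8 and compound 2 (`O=C(Nc1ccc(F)c(C(F)(F)F)c1)Nc1ccccn1`) gives 3.7 while compound 3 (`Cc1cc(NC(=O)Nc2ccc(F)c(C(F)(F)F)c2)on1`) gives 3.2 as the lowest of the three, beyond the scatter of both others. Compound 4 (`O=C(Nc1ccncc1)Nc1ccc(F)c(C(F)(F)F)c1`) has not yet been measured. The change leading to it (pyridin-4-yl in place of 3-methyl-1,2-oxazol-5-yl on an amide-type nitrogen) puts pyridin-4-yl in place of 3-methyl-1,2-oxazol-5-yl on an amide-type nitrogen. Among the measured compounds shown here, one measured step bears on this change: a number 0.50 log units lower from compound 2 to compound 3 (beyond the scatter) is modest and involves the same departing group, but in the opposite direction and with pyridin-2-yl rather than pyridin-4-yl. Read backwards it would point upward, yet the data hold no step for pyridin-4-yl itself, so it transfers only loosely. The expectation is therefore no step beyond the scatter, with an estimated a number 0.20 log units lower from compound 3 to compound 4 (within the scatter) in this assay and a wide margin on both sides. For compound 4 the estimated value is 3 with an expected range from 2.6 to 3.5 in this assay until the measurement is known.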

Compound 4, distribution coefficient: 3.2
For compound 4 the middle estimate is 0.20 log units below the measured one; measured number inside the range.
By their numbers in this assay, from the lowest: compounds 3 and 4 (each within the scatter of the next); then compounds 2 and 1 (each within the scatter of the next).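

In this assay the exchange of 3-methyl-1,2-oxazol-5-yl for pyridin-4-yl on an amide-type nitrogen gives (no change at the digits printed from compound 3 to compound 4 (within the scatter)), so these two rings are not told apart at this position. The same place is not indifferent to every ring, however: pyridin-4-yl in place of pyridin-2-yl gives (a number 0.50 log units lower from compound 2 to compound 4 (beyond the scatter)), and the read-out also answers to a second place, where hydrogen in place of trifluoromethyl on an aromatic carbon gives (a number 0.60 log units lower from compound 1 to compound 4 (beyond the scatter)). Nothing measured here accounts for these steps.

The compounds shown leave open how a carboxylic acid or an amine in place of that trifluoromethyl would read in this assay. They also leave open where pyridin-3-yl on the amide-type nitrogen would fall.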